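The source may report more compounds than this note shows. Statements on the series, on what has been measured and on what is new or still open speak of the compounds shown alone.

Working notes on the series. Two members have been measured in an assay on Prostate gland for inhibition of steroid 5-alpha-reductase (Rattus norvegicus); on this read-out lower numbers stand for stronger inhibition and higher numbers for weaker inhibition. Compound 1 `CCCCCC(CCCCC)n1ccc2cc(/C(C)=C/C(=O)Nc3ccccc3OCCCC(=O)O)ccc21` gives 25 nM. Among the measured compounds shown here, compound 2 `COc1ccc(Cn2ccc3cc(/C(C)=C/C(=O)Nc4ccccc4OCCCC(=O)O)ccc32)cc1` gives 480 nM, the highest of the two numbers; the one step recorded, a 19-fold higher number from compound 1 to compound 2 (1.28 log units; beyond the scatter), shows that exchanging the 1-pentylhexyl on the aromatic nitrogen for 4-methoxybenzyl costs potency well beyond the scatter.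

The next member is compound 3 `CCCCC(c1ccccc1)n1ccc2cc(/C(C)=C/C(=O)Nc3ccccc3OCCCC(=O)O)ccc21`, which differs from compound 2 by 1-phenylpentyl in place of 4-methoxybenzyl on an aromatic nitrogen. The 1-phenylpentyl group combines a phenyl ring, as found in the 4-methoxybenzyl of compound 2, with a pentyl chain of the kind present in the 1-pentylhexyl of compound 1, and it drops the methoxy group. For the measured compounds named here, only the step from compound 1 to compound 2 bears on this change, and it was large. Reversing part of that change is therefore expected to move the number downward, though by less than the full step, because 25 nM for compound 1 marks the most that has been regained so far. Compound 3 is estimated at 70 nM, within 25 nM to 200 nM, corresponding to an expected step of a 6.9-fold lower number from compound 2 to compound 3 (0.84 log units; beyond the scatter).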

Compound 3, half-maximal inhibitory concentration: 9.8 nM
Compound 3: the middle estimate sits 7.1-fold (0.85 log units) above what was measured; the whole stated range lies above it.
By their numbers in this assay, from the lowest: compound 3; then compound 1; then compound 2.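

At this position on the aromatic nitrogen, the exchange of 4-methoxybenzyl for 1-phenylpentyl gives a 49-fold lower number from compound 2 to compound 3 (1.69 log units; beyond the scatter) and does more than recover the potency lost with compound 2, since the comparison with the 1-pentylhexyl group gives a 2.6-fold lower number from compound 1 to compound 3 (0.41 log units; beyond the scatter) and leaves compound 3 with the lowest number of the three. A phenyl ring in this substituent is therefore compatible with a low number, and the high number of compound 2 cannot be read as a penalty for any aromatic ring here: compound 2 and compound 3 both carry one, yet they stand at opposite ends of the series. No measurement on hand bears on why the number moves at this position.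

The step from compound 2 to compound 3 removes the methoxy group and adds the pentyl chain in one exchange, so the compounds shown do not divide the gain between these two parts. Open as well is how an unsubstituted benzyl, a 1-phenylethyl, a 1-phenylhexyl or a 1-cyclohexylpentyl group on this nitrogen would compare with 1-phenylpentyl.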